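Sulfonyl-bearing chain variation on the shared core

The compounds below may be only part of what the source reports. "The series", "measured", "known", "first", "only" and "open" are said of these compounds alone.

For the measured compounds named here, compound 2 `CN(C)S(=O)(=O)CCNc1nonc1/C(=N/O)Nc1ccc(F)c(Br)c1` gives 17 nM in an assay on HeLa cells for inhibition of Indoleamine 2,3-dioxygenase 1 (Homo sapiens), read by spectrophotometry, with a stated time of 24 h (on this read-out higher numbers stand for an effect only at larger amounts of compound and lower numbers for an effect already at smaller amounts), the lowest of the two numbers so far; its nearest neighbour is compound 1 `NNc1nonc1/C(=N/O)Nc1ccc(F)c(Br)c1`, which gives 556 nM. Going by the values given here, the only measured step, a 33-fold lower number from compound 1 to compound 2 (1.51 log units; beyond the scatter), shows that a 2-(dimethylsulfamoyl)ethyl chain in place of amino on a nitrogen on an aromatic ring brings a large gain. Compound 3 `NS(=O)(=O)CCCNc1nonc1/C(=N/O)Nc1ccc(F)c(Br)c1` is not yet measured; it differs from compound 2 by sulfamoylmethyl in place of dimethylsulfamoyl on a saturated chain carbon, two bonds along the chain from a nitrogen on an aromatic ring. Among the compounds with values here, no measured step covers this exchange directly: both compound 2 and compound 3 carry a chain with a sulfur-oxygen-nitrogen group on the nitrogen on the aromatic ring, and the step from compound 1 to compound 2 speaks only to the presence of such a chain, not to its length or to its substitution. Compound 3 is therefore expected to stay close to compound 2, with an estimated step of a 1.3-fold higher number from compound 2 to compound 3 (0.11 log units; within the scatter) that need not exceed the scatter. The estimate for compound 3 is 22 nM, expected within 7 nM to 70 nM.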

Compound 3, half-maximal effective concentration: 15 nM
Compound 3: middle estimate off by 1.5-fold (0.17 log units), on the high side; measured number inside the range.
By their numbers in this assay, from the lowest: compounds 3 and 2 (each within the scatter of the next); then compound 1.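

On the saturated chain carbon, two bonds along the chain from a nitrogen on an aromatic ring, sulfamoylmethyl in place of dimethylsulfamoyl gives in this assay a 1.1-fold lower number from compound 2 to compound 3 (0.05 log units; within the scatter). The 2-(dimethylsulfamoyl)ethyl and 3-sulfamoylpropyl chains are therefore not told apart here, although the exchange goes from 0 to 1 hydrogen-bond donor. The large step over amino is also not confined to one chain: 3-sulfamoylpropyl in place of amino gives a 37-fold lower number from compound 1 to compound 3 (1.57 log units; beyond the scatter). No measurement on hand accounts for these results.

Chain length and substitution on the sulfonamide nitrogen change together from compound 2 to compound 3, so neither can be read alone. Going by these compounds, whether a carboxylic acid or an amine at the end of the chain, or a longer chain, would stay in this range remains open.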